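The source may report more compounds than this note shows. Statements on the series, on what has been measured and on what is new or still open speak of the compounds shown alone.

Of the compounds shown here, three share one core and have been tested in a functional assay on CHO cells for agonist activity at Free fatty acid receptor 1 (Homo sapiens), read by FLIPR and calcium flux, tested at 100 nM; on this read-out lower numbers stand for a weaker effect and higher numbers for a stronger effect at the one concentration tested. Compound 1 `O=C(O)CC1COc2cc(OCc3nnc(-c4ccccc4)o3)ccc21` gives 1.54%, and compound 2 `O=C(O)CC1COc2cc(OCc3nc(-c4ccccc4)cs3)ccc21` gives 0.16%; both lie close to zero. Compound 3 `Cc1nc(-c2cccs2)sc1COc1ccc2c(c1)OCC2CC(=O)O` gives 35.2%, the highest of the three numbers. Its nearest neighbour on this scale is compound 1, whose number is lower by an amount beyond the scatter, and the furthest is compound 2, lower by an amount also beyond the scatter. No two of these compounds differ in only one place, so no single structural step can be read off from them.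

Compound 4 `Cc1nc(-c2ccccc2Cl)sc1COc1ccc2c(c1)OCC2CC(=O)O` is not yet measured. It keeps the core of compound 3 and changes one group: 2-chlorophenyl in place of thiophen-2-yl on an aromatic carbon. Because compound 3 gives 35.2% with a thiophen-2-yl at that place, and a six-membered carbon ring of similar size replaces it, the step of a number 7.2 percentage points lower from compound 3 to compound 4 (within the scatter) is expected to stay small, with no clear direction beyond the scatter. Compound 4 is therefore estimated at 28%, within a range from 5% to 60%.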

Compound 4, a percentage reported as activity, at one concentration (the size of the read-out at that concentration, not a potency): 12.4%
Compound 4: middle estimate off by 15.6 percentage points, on the high side; the measured number falls inside the stated range.
By their numbers in this assay, from the lowest: compounds 2 and 1 (each within the scatter of the next); then compound 4; then compound 3.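

Swapping thiophen-2-yl for 2-chlorophenyl, on the aromatic carbon next to the ring nitrogen and next to the ring sulfur, gives the first single-place comparison here: in this assay, it produces a number 22.8 percentage points lower from compound 3 to compound 4 (beyond the scatter). The two aromatic groups are therefore not interchangeable at this position, although a six-membered ring of carbon only still leaves a clear effect, with compound 4 at 12.4%. No measurement shown explains this drop.

The step changes the ring and adds a chlorine together, so the compounds shown do not separate the contribution of each; an unsubstituted phenyl at this place would address that. As far as these compounds go, whether a 3-chlorophenyl, a 4-chlorophenyl or a pyridine ring would retain the effect of thiophen-2-yl also remains open.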